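Swapping Methoxy for Chloro on an Azido Nucleoside Core

This account rests on a few compounds, and the source may have more. Where it says the series, first, only, none or still open, it means among the compounds named here.

Compound 1 `COc1nc(NC2CC2)c2ncn([C@H]3C[C@H](N=[N+]=[N-])[C@@H](CO)O3)c2n1` and compound 2 `[N-]=[N+]=N[C@H]1C[C@H](n2cnc3c(NC4CC4)nc(Cl)nc32)O[C@@H]1CO` share one core and differ by a single change on it. In an ADME assay on PBMC cells (Homo sapiens) for cytotoxicity, with a stated time of 5 days (a lower number here means a stronger inhibitor, a higher number a weaker inhibitor), compound 1 gives only a limit of the assay, not a number: > 100000 nM. Compound 2 gives 35300 nM in this assay. The step between them is an at least 2.8-fold lower number from compound 1 to compound 2 (0.45 log units; beyond the scatter), and the change behind it is chloro in place of methoxy on an aromatic carbon. One point to keep in view is the limit of > 100000 nM in this assay, at which 1 of the 3 values shown sits, so the true size of that step is only known as a lower bound.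

Compound 3 `COc1nc(F)nc2c1ncn2[C@H]1C[C@H](N=[N+]=[N-])[C@@H](CO)O1` carries a different core; the difference between the two cores is not broken down here. In this assay, among the measured compounds shown here, compound 3 gives 9400 nM, the lowest of the two numbers measured so far.

Compound 4 `[N-]=[N+]=N[C@H]1C[C@H](n2cnc3c(Cl)nc(F)nc32)O[C@@H]1CO` has not yet been measured. It differs from compound 3 by chloro in place of methoxy on an aromatic carbon. For the measured compounds named here, this is the same kind of change as the one from compound 1 to compound 2, but its surroundings differ: in compound 3 the carbon is next to the ring nitrogen, ortho to a fused ring, meta to a fluoro group, meta to a fused ring and opposite the ring nitrogen, whereas in compound 1 it lies between two ring nitrogen atoms, meta to a cyclopropylamino group, meta to a fused ring and para to a fused ring.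

Given the step of an at least 2.8-fold lower number from compound 1 to compound 2 (0.45 log units; beyond the scatter), compound 4 is expected to move by a 2.8-fold lower number from compound 3 to compound 4 (0.45 log units; beyond the scatter). The estimated value for compound 4 in this assay is 3300 nM, expected to fall between 1000 nM and 12000 nM.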

Compound 4, half-maximal inhibitory concentration: 7200 nM
Compound 4: the middle estimate sits 2.2-fold (0.34 log units) below what was measured; low and high end bracket the measured number.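

In this assay, chloro in place of methoxy on the core of compound 3 gives a 1.3-fold lower number from compound 3 to compound 4 (0.12 log units; within the scatter), and since that step is within the scatter, it cannot be told apart from no change at all. This is a weaker result than the clear drop seen on the core of compound 1, yet the two steps cannot be called different, as one end of the earlier step is only a limit: the same change on two cores in this assay, an at least 2.8-fold lower number (0.45 log units; beyond the scatter) from compound 1 to compound 2 and a 1.3-fold lower number (0.12 log units; within the scatter) from compound 3 to compound 4; the limit leaves it open whether they differ. Among the compounds shown here, the pair therefore does not show that the change carries over from one core to the other at the same size, nor that it fails to carry over, and with only two examples, each on its own core and with the swap in a different place, no rule for the series can be drawn from it.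

Still open, on these data alone, is whether a different halogen such as bromo, or a small carbon group such as methyl, would move the number in this assay more than chloro does when it replaces methoxy. The compounds shown also leave open how the same swap would behave on a core that carries an amine or a longer chain in place of the fluoro group.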